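The source may report more compounds than this note shows. Statements on the series, on what has been measured and on what is new or still open speak of the compounds shown alone.

Measured so far in an assay on HEK293 cells for displacement of a labelled ligand from Neuronal acetylcholine receptor; alpha4/beta2 (Homo sapiens); on this read-out lower numbers stand for stronger inhibition and higher numbers for weaker inhibition:
compound 1 `Clc1cncc(N2CCCNCCC2)c1` — 2 nM
compound 2 `COc1cc(N2CCCNCC2)cnc1Cl` — 0.676 nM
compound 3 `C=COc1cncc(N2CCNCC2)c1` — 191 nM

Compound 2 gives the lowest number of the three. Compound 1 comes nearest, its number higher by a gap beyond the usual scatter; compound 3 lies far off, beyond the scatter by a wide margin.

Compound 4 `Clc1ncc(N2CCCNCC2)cc1Br` is not yet measured. From compound 2 it differs in one place: bromo in place of methoxy on an aromatic carbon. For the measured compounds named here, no measured pair isolates that exchange, so no step can be quoted for it. Given that the two halogen-bearing compounds 1 and 2 both sit at low numbers, only a small shift, if any beyond the scatter, is expected, most plausibly towards a somewhat higher number.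

Compound 4 is therefore expected to give about 1.5 nM in this assay, within 0.4 nM to 6 nM, an estimated step of a 2.2-fold higher number from compound 2 to compound 4 (0.35 log units; beyond the scatter).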

Compound 4, half-maximal inhibitory concentration: 1.41 nM
The estimate for compound 4 lay 1.1-fold (0.03 log units) above the measured number; measured number inside the range.
By their numbers in this assay, from the lowest: compound 2; then compounds 4 and 1 (each within the scatter of the next); then compound 3.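

In this assay, for the compounds shown here, bromo in place of methoxy on this aromatic carbon, ortho to the chloro group, gives a 2.1-fold higher number from compound 2 to compound 4 (0.32 log units; beyond the scatter) and is the first exchange isolated at a single place. The position therefore accepts the loss of the methoxy oxygen and its hydrogen-bond acceptor, with compound 4 still at 1.41 nM in the same assay. No evidence on the reason for the step is at hand. Going by these compounds, whether an amine, a hydroxy group or a longer alkoxy chain on this carbon would keep the number this low remains open.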